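The compounds below may be only part of what the source reports. "The series", "measured", "known", "first", "only" and "open" are said of these compounds alone.

Measured in an ADME assay on L02 cells (Homo sapiens) for cytotoxicity, read by MTT assay, with a stated time of 24 h; a higher number here means a weaker inhibitor, a lower number a stronger inhibitor:
- Compound 1 `COc1cc(/C=C2\CN(S(=O)(=O)c3ccc(F)cc3)C/C(=C\c3ccccc3F)C2=O)cc(OC)c1OC`: 17600 nM
- Compound 2 `COc1cc(/C=C2\CN(S(=O)(=O)c3ccc(F)cc3)C/C(=C\c3cc(OC)c(OC)c(OC)c3)C2=O)cc(OC)c1`: 12300 nM

Among the compounds with values here, only two compounds have been measured in this assay, and compound 1, at 17600 nM, stands within the scatter of compound 2. Compound 3 `COc1cc(/C=C2\CN(S(=O)(=O)c3ccc(NC(C)=O)cc3)C/C(=C\c3ccccc3F)C2=O)cc(OC)c1OC` keeps the core of compound 1 and changes one group: acetamido in place of fluoro on an aromatic carbon. In words, this is acetamido in place of fluoro on an aromatic carbon, or 4-fluorophenyl to 4-acetamidophenyl. Within the data shown here, the only measured step, a 1.4-fold lower number from compound 1 to compound 2 (0.16 log units; within the scatter), replaces 2-fluorophenyl with 3,5-dimethoxyphenyl at another place, so it bears on this change only loosely. Among the measured compounds shown here, no measured step touches the 4-fluorophenyl group, so no shift beyond the scatter can be predicted in either direction. The expected step is a 1.2-fold lower number from compound 1 to compound 3 (0.07 log units; within the scatter). Compound 3 is estimated at 15000 nM, with an expected range from 6000 nM to 35000 nM.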

Compound 3, half-maximal inhibitory concentration: 14000 nM
The estimate for compound 3 lay 1.1-fold (0.03 log units) above the measured number; the range from low to high includes it.
By their numbers in this assay, from the lowest: compounds 2, 3 and 1 (each within the scatter of the next).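

In this assay, within the data shown here, the first change at the 4-fluorophenyl group, 4-fluorophenyl to 4-acetamidophenyl, gives a 1.3-fold lower number from compound 1 to compound 3 (0.10 log units; within the scatter). This shows that on this aromatic carbon, para to a large group, fluoro can give way to the larger acetamido group, which carries a hydrogen-bond donor and a hydrogen-bond acceptor, with no shift beyond the scatter, something the earlier pair could not show because it differed only at the 2-fluorophenyl group. Nothing measured here bears on the reason for this result.

From the compounds shown here alone, whether the same holds for an amine, a carboxylic acid or a longer acyl chain at this place remains open. The compounds shown also leave open whether acetamido would give a similar result in a compound carrying the 3,5-dimethoxyphenyl group of compound 2.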